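The source may hold more compounds than are shown below. What is called first, only, known or untested is meant among the compounds shown, and "the series" means these compounds.

Measured so far in an ADME assay on the whole organism (plasma, strain 129/SvEvBrd x C57BL/6) for pharmacokinetics, with Mus musculus as the target, at a dose of 10 mg/kg by the oral route; a lower number here means less compound in the circulation, a higher number more compound in the circulation at the dose given:

- compound 1 `CC(O)c1nc([C@@H](O)[C@H](O)[C@H](O)CO)c[nH]1` gives 10300 ng.h/mL
- compound 2 `OC[C@@H](O)[C@@H](O)[C@H](O)c1c[nH]c(-c2cscn2)n1` gives 1570 ng.h/mL
- compound 3 `OC[C@@H](O)[C@@H](O)[C@H](O)c1c[nH]c(-c2ncon2)n1` gives 820 ng.h/mL

Compound 3, at 820 ng.h/mL, cannot be told apart from compound 2, since the step of a 1.9-fold lower number from compound 2 to compound 3 (0.28 log units; within the scatter). Compound 1 stands well clear of it, and the step of a 13-fold lower number from compound 1 to compound 3 (1.10 log units; beyond the scatter).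

The next compound keeps the shared core and changes only the ring on the aromatic carbon. Compound 4 `Cn1cnc(-c2nc([C@@H](O)[C@H](O)[C@H](O)CO)c[nH]2)c1` carries 1-methyl-1H-imidazol-4-yl in place of 1,2,4-oxadiazol-3-yl, and the count of that change is 1-methyl-1H-imidazol-4-yl in place of 1,2,4-oxadiazol-3-yl on an aromatic carbon.

Within the data shown here, the closest precedent is the swap of one aromatic ring for another, the step of a 1.9-fold lower number from compound 2 to compound 3 (0.28 log units; within the scatter), which produced no measurable difference. The larger steps, a 6.6-fold lower number from compound 1 to compound 2 (0.82 log units; beyond the scatter) and a 13-fold lower number from compound 1 to compound 3 (1.10 log units; beyond the scatter), replace 1-hydroxyethyl with a ring, so they bear on this change only indirectly. Compound 4 keeps a ring at this place, so it is expected to stay near compound 2 and compound 3 rather than approach compound 1. With only these few compounds, this expectation remains loose.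

The expected change is a 1.5-fold higher number from compound 3 to compound 4 (0.17 log units; within the scatter), which means no clear shift.

For compound 4 the estimated value is 1200 ng.h/mL, with an expected range from 400 ng.h/mL to 3600 ng.h/mL.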

Compound 4, area under the concentration-time curve: 698 ng.h/mL
Compound 4: middle estimate off by 1.7-fold (0.24 log units), on the high side, within the range that was stated.
By their numbers in this assay, from the lowest: compounds 4, 3 and 2 (each within the scatter of the next, the first and the last beyond it); then compound 1.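

In this assay a third aromatic ring at this place, the 1-methyl-1H-imidazol-4-yl group, behaves much like 1,2,4-oxadiazol-3-yl: a 1.2-fold lower number from compound 3 to compound 4 (0.07 log units; within the scatter) gives no clear shift, even though the two rings differ in their hetero atoms and the new ring carries a methyl group. Ring choice is still not entirely without consequence, as a 2.2-fold lower number from compound 2 to compound 4 (0.35 log units; beyond the scatter) lies just beyond the scatter and is the first ring-for-ring swap here that can be told apart, though only modestly. The large gap to the hydroxyethyl compound also holds for this third ring, with a 15-fold lower number from compound 1 to compound 4 (1.17 log units; beyond the scatter) joining a 13-fold lower number from compound 1 to compound 3 (1.10 log units; beyond the scatter) and a 6.6-fold lower number from compound 1 to compound 2 (0.82 log units; beyond the scatter) without any of the three ring compounds going against the pattern, but nothing available explains why these rings sit so far from 1-hydroxyethyl.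

The compounds shown leave open whether the higher number of compound 1 goes with the hydroxyl group or with the open chain that carries it, and a plain ethyl or a 1-methoxyethyl group at this place would separate the two. From the compounds shown here alone, how an amine or a carboxylic acid at this place would compare also remains unknown.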